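This account rests on a few compounds, and the source may have more. Where it says the series, first, only, none or still open, it means among the compounds named here.

Compound 3 `Cc1cccc(N2CCN(C(=O)C(C)N3C(=O)CCC3=O)CC2)c1` belongs to a small set of three compounds that share one core and differ only in the aromatic group attached to the ring nitrogen. In a functional assay on the whole organism (strain Swiss) with Mus musculus as the target, in the maximal electroshock model, with a stated time of 0.5 h, at a dose of 300 mg/kg by the intraperitoneal route (a lower number here means a weaker effect, a higher number a stronger effect of the compound at the dose given), compound 3 gives 50%. Compound 1 `COc1cccc(N2CCN(C(=O)C(C)N3C(=O)CCC3=O)CC2)c1` gives 50%, and compound 2 `CC(C(=O)N1CCN(c2ccccc2F)CC1)N1C(=O)CCC1=O` gives 50%, so compound 3 stands level with both at the digits shown. Each single-point swap among these three left the read-out unchanged: no change at the digits printed from compound 1 to compound 2 (within the scatter), no change at the digits printed from compound 1 to compound 3 (within the scatter) and no change at the digits printed from compound 2 to compound 3 (within the scatter).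

The next compound, compound 4 `CC(C(=O)N1CCN(c2ccccc2Cl)CC1)N1C(=O)CCC1=O`, has not yet been measured. It differs from compound 3 in one place: 2-chlorophenyl in place of 3-methylphenyl on an amine nitrogen in a ring. The step that bears most directly on this change is the earlier swap of the aromatic group on the same ring nitrogen, no change at the digits printed from compound 2 to compound 3 (within the scatter), which stayed within the scatter, as did no change at the digits printed from compound 1 to compound 2 (within the scatter). The expected step is therefore none beyond the scatter, no change at the digits printed from compound 3 to compound 4 (within the scatter). Compound 4 is expected to give 50%, with an estimated range from 35% to 65%.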

Compound 4, a percentage reported as activity, at one dose (the size of the read-out at that dose, not a potency): 0%
Compound 4: middle estimate off by 50 percentage points, on the high side, and the stated range ends above it.
By their numbers in this assay, from the lowest: compound 4; then compounds 1, 2 and 3 (each within the scatter of the next).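

In this assay, the earlier swaps on this ring nitrogen suggested that the aromatic group could vary freely, but compound 4 shows that it cannot: 2-chlorophenyl in place of 3-methylphenyl gives a number 50 percentage points lower from compound 3 to compound 4 (beyond the scatter) in the read-out. The closest comparison is chloro in place of fluoro on an aromatic carbon, which gives a number 50 percentage points lower from compound 2 to compound 4 (beyond the scatter) and shows that exchanging one halogen for another on this ring can matter. The replacement of 3-methoxyphenyl points the same way, with a number 50 percentage points lower from compound 1 to compound 4 (beyond the scatter) as a further drop that the three earlier compounds, level with one another, gave no hint of.

No measurement shown here explains this loss. From the compounds shown here alone, how a 2-bromophenyl group or a plain phenyl group on the same ring nitrogen would behave in this assay also remains open.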